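Changing one drawn configuration in a lipophilicity series

The source may report more compounds than this note shows. Statements on the series, on what has been measured and on what is new or still open speak of the compounds shown alone.

Of the compounds shown here, two sharing the same core have been measured in a physicochemical assay for lipophilicity, read by HPLC; on this read-out lower numbers stand for lower lipophilicity and higher numbers for higher lipophilicity. Compound 1 `CC(=O)NC[C@H]1CN(c2ccc(OC[C@H](O)CNc3ccc(C#N)cc3)c(F)c2)C(=O)O1` carries a benzonitrile at the far end of its chain, and in this assay compound 1 gives 1.29. Compound 2 `CC(=O)NC[C@H]1CN(c2ccc(OC[C@@H](O)CNc3ccncc3)c(F)c2)C(=O)O1` carries a pyridine in that position instead, and in this assay compound 2 gives -0.04. Of the two numbers, compound 2 stands lowest, with compound 1 lying higher by an amount beyond the usual scatter of the measurement. For the measured compounds named here, no single-point step between these two measured compounds is known, so nothing about the size of such steps can be read directly from them.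

Compound 3 `CC(=O)NC[C@H]1CN(c2ccc(OC[C@H](O)CNc3ccncc3)c(F)c2)C(=O)O1` is next. Compared with compound 2, (the two compounds have the same atoms and bonds and differ only in configuration as drawn: 1 of 2 stereo elements differ; a stereocentre at a saturated chain carbon is drawn S in compound 2 and R in compound 3). Everything else, every atom and bond, stays the same. In this assay such a change in drawn configuration is expected to give no step beyond the scatter, so the step from compound 2 to compound 3 is expected to be no change at the digits printed from compound 2 to compound 3 (within the scatter). On that basis compound 3 is estimated at -0.04, within a range from -0.34 to 0.26.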

Compound 3, partition coefficient: 0.02
Estimate against measurement, compound 3: 0.06 log units below; the range from low to high includes it.
By their numbers in this assay, from the lowest: compounds 2 and 3 (each within the scatter of the next); then compound 1.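

Redrawing the saturated chain carbon from S to R gives a number 0.06 log units higher from compound 2 to compound 3 (within the scatter) in this assay, so at this position the drawn configuration produces no step larger than repeated measurements would show, and the comparison is a clean one because nothing else separates the pair: the fact that compounds 2 and 3 differ only in the configuration as drawn. The result also supplies a comparison in one place for the far end of the chain, which the first two compounds could not offer, as they differed in that group and in configuration together. With pyridin-4-yl in place of 4-cyanophenyl on an amine nitrogen, the number moves as a number 1.27 log units lower from compound 1 to compound 3 (beyond the scatter), a large step that now involves that swap alone.

The pair of configurations shown here carries pyridin-4-yl only, so whether a compound with 4-cyanophenyl would be just as indifferent to the drawn configuration remains open. Also open is where a plain phenyl or a pyridin-3-yl on that amine nitrogen would fall in this assay relative to the two groups shown, and so whether the large step belongs to the ring nitrogen, to the nitrile, or to both.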